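This account rests on a few compounds, and the source may have more. Where it says the series, first, only, none or still open, it means among the compounds named here.

For the measured compounds named here, compound 1, `O=c1c(SC(=S)N2CCCCC2)coc2ccccc12`, is one of two compounds so far measured in a functional assay on SW480 cells (Homo sapiens) for antiproliferative activity, read by MTT assay, with a stated time of 72 h (a higher number here means a weaker inhibitor, a lower number a stronger inhibitor), where compound 1 gives 16300 nM. Its companion, compound 2, `COc1ccc2oc(CSC(=S)N(C(C)C)C(C)C)cc(=O)c2c1`, gives 7200 nM in this assay, so of the two numbers compound 1 holds the higher one, and the gap between them lies beyond the scatter. Going by the values given here, these two compounds differ in several places at once, so no single step links them. Compound 3, `O=c1c(SC(=S)N2CCCC2)coc2ccccc12`, has not yet been measured; it differs from compound 1 in one place: pyrrolidin-1-yl in place of piperidin-1-yl on a thiocarbonyl carbon. Among the compounds with values here, no comparable step exists among the measured compounds, so the size of this change in this assay is uncertain; a small step, in either direction or none beyond the scatter, is expected. For compound 3 the expected value in this assay is 14000 nM, with a range from 6000 nM to 32000 nM. This estimate means a step of a 1.2-fold lower number from compound 1 to compound 3 (0.07 log units; within the scatter) is expected.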

Compound 3, half-maximal inhibitory concentration: > 25000 nM
Compound 3 was reported as a limit; the forecaster's own chance of this, stated with the estimate: 5%; middle value at least 1.7-fold (0.25 log units) away from the limit.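

For the compounds shown here, the one-place change from piperidin-1-yl to pyrrolidin-1-yl on a thiocarbonyl carbon gives an at least 1.5-fold higher number from compound 1 to compound 3 (0.18 log units; that floor lies within the scatter), the first single change that can be read at this position. In this assay compound 3 gives > 25000 nM, which is a limit and not a number: the limit of > 25000 nM in this assay, at which 1 of the 3 values shown sits. The five-membered ring therefore brings no lower number than the six-membered ring, but only a floor is known, so the true size of the step remains undetermined.

Going by these compounds, whether a morpholine ring, with its added oxygen, or an open-chain diethylamino group on the same thiocarbonyl carbon would move the number in this assay stays open. Compound 2 differs from compound 1 in several places at once, so it cannot show how much this position alone contributes.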